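A few compounds are considered here, and "the series" means these few. Any claim that something is new, unique, unknown or untested is made for them only; others in the source may bear on it.

In an ADME assay on MDCK cells (Canis lupus familiaris) for cytotoxicity, read by MTT assay, with a stated time of 72 h (a higher number here means that more compound is tolerated, a lower number that less compound is tolerated), compound 2 `C=C(CC(=O)Nc1cc(F)ccc1F)C(=O)O` gives > 110000 nM, and this is a limit of the assay rather than a number. Compound 1 `C=C(CC(=O)Nc1ccc(C(F)(F)F)cc1F)C(=O)Nc1ccc(C(F)(F)F)cc1F`, which carries trifluoromethyl groups, gives > 110000 nM, which is also a limit. The record so far is therefore simple: the limit of > 110000 nM in this assay, at which 2 of the 2 values shown sit.

The next compound, compound 3 `C=C(CC(=O)Nc1cc(C(F)(F)F)ccc1F)C(=O)O`, differs from compound 2 in a single place: trifluoromethyl in place of fluoro on an aromatic carbon. In words, trifluoromethyl stands in place of fluoro on an aromatic carbon, para to a fluoro group. For the measured compounds named here, no measured pair of compounds shows this swap directly, so any expectation rests on little. Going by the values given here, still, the one compound with trifluoromethyl, compound 1 at > 110000 nM, gives no sign that this group lowers the amount tolerated. In this assay, no change beyond the usual scatter is expected, and another limit is the most likely report. The estimated step is a number no higher from compound 2 to compound 3 (the limit leaves the size open). The expected value for compound 3 is 110000 nM, with an estimated range from 55000 nM to 220000 nM.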

Compound 3, half-maximal cytotoxic concentration: > 110000 nM
Compound 3 ended at the assay's limit; the forecaster's own chance of this, stated with the estimate: 80%; the middle value sits exactly at the limit.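

Compound 2 and compound 3 both end at a limit in this assay rather than at a number, so no step can be read for trifluoromethyl in place of fluoro. The record now reads: the limit of > 110000 nM in this assay, at which 3 of the 3 values shown sit. The compounds shown leave open how much of each compound is tolerated, and whether this swap changes that amount at all.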